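The source may hold more compounds than are shown below. What is called first, only, known or untested is meant among the compounds shown, and "the series" means these compounds.

Working notes on the series, read in a functional assay on MCF7 cells (Homo sapiens) for inhibition, read by sulforhodamine B assay, with a stated time of 48 h, tested at 50 uM; a lower number here means less inhibition of growth, a higher number more inhibition of growth at the concentration tested. Compound 1 `COc1cc2c(cc1CC=C(C)C)C(=O)C[C@@H](c1ccc(Oc3ccc(F)cc3)cc1)O2` gives 37%, compound 2 `COc1cc2c(cc1CC=C(C)C)C(=O)C[C@@H](c1ccc(Oc3cccc([N+](=O)[O-])c3)cc1)O2` gives 53% and compound 3 `CCOc1ccc([C@@H]2CC(=O)c3cc(CC=C(C)C)c(OC)cc3O2)cc1` gives 57%. Compound 3 shares the upper level with compound 2, as a number 4 percentage points higher from compound 2 to compound 3 (within the scatter) shows. Compound 1 lies lower, with a number 20 percentage points higher from compound 1 to compound 3 (beyond the scatter) and a number 16 percentage points higher from compound 1 to compound 2 (beyond the scatter).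

Compound 4 `C#CCOc1ccc([C@@H]2CC(=O)c3cc(CC=C(C)C)c(OC)cc3O2)cc1` carries ethynyl in place of methyl on a saturated chain carbon bound to an oxygen on an aromatic ring, which reads as ethyl to propargyl. All three measured steps change the group on that same oxygen, but the two beyond the scatter involve the 4-fluorophenyl of compound 1, a far larger exchange than this one. The expected result is a number 3 percentage points lower from compound 3 to compound 4 (within the scatter), with no shift expected beyond the scatter. The estimate for compound 4 is 54%, with an expected range of 42% to 66%.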

Compound 4, percent growth inhibition at one concentration: 68%
Compound 4: the middle estimate sits 14 percentage points below what was measured; the measured number lies above the stated range.
By their numbers in this assay, from the lowest: compound 1; then compounds 2 and 3 (each within the scatter of the next); then compound 4.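

Ethynyl in place of methyl on this saturated chain carbon gives a number 11 percentage points higher from compound 3 to compound 4 (beyond the scatter) in this assay, so a small exchange at this position moves the read-out, whereas the earlier steps beyond the scatter all involved the 4-fluorophenyl of compound 1. Propargyl also separates from 3-nitrophenyl, with a number 15 percentage points higher from compound 2 to compound 4 (beyond the scatter) as the step, and from 4-fluorophenyl, with a number 31 percentage points higher from compound 1 to compound 4 (beyond the scatter) as the step, although ethyl and 3-nitrophenyl remain within the scatter of each other. No measurement at hand accounts for this shift.

As far as these compounds go, whether a longer chain ending in a triple bond, or a nitrile in place of the ethynyl, holds this level remains open.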